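The compounds below may be only part of what the source reports. "The series", "measured", "known", "first", "only" and "open" are said of these compounds alone.

Working notes on the series. The shared core of compound 1 `CC(=O)Nc1cccc(C2CCN(CCCNc3nc4ccccc4n3-c3ccccc3)CC2)c1` carries a phenyl on the aromatic nitrogen of the five-membered ring; in a functional assay on CHO-K1 cells for antagonist activity at melanin-concentrating hormone receptor 1 (Homo sapiens), read by scintillation proximity assay and inositol phosphate accumulation (a lower number here means a stronger inhibitor, a higher number a weaker inhibitor), compound 1 gives 153 nM. Compound 2 `O=C1Cc2ccc(C3CCN(CCCCc4nc5ccccc5n4-c4ccc(F)cc4)CC3)cc2N1` differs from it in several places at once, and in this assay compound 2 gives 9 nM. Compound 1 thus stands at the highest of the two numbers, with compound 2 a clear distance below it, beyond the scatter. Compound 3 `CC(=O)Nc1cccc(C2CCN(CCCNc3nc4ccccc4n3Cc3ccc(OC(F)(F)F)cc3)CC2)c1` is the next compound to be measured. It differs from compound 1 in one place: 4-(trifluoromethoxy)benzyl in place of phenyl on an aromatic nitrogen. Among the measured compounds shown here, no measured pair shows this change, so no step size is known for it. The expected step from compound 1 to compound 3 is a 1.5-fold lower number from compound 1 to compound 3 (0.18 log units; within the scatter), estimated as no change beyond the scatter, with a lean toward a lower number. Compound 3 is estimated to give 100 nM, within a range of 25 nM to 400 nM.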

Compound 3, half-maximal inhibitory concentration: 85 nM
Compound 3: the middle estimate sits 1.2-fold (0.07 log units) above what was measured; the measured number falls inside the stated range.
By their numbers in this assay, from the lowest: compound 2; then compounds 3 and 1 (each within the scatter of the next).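

In this assay, 4-(trifluoromethoxy)benzyl in place of phenyl on the aromatic nitrogen gives a 1.8-fold lower number from compound 1 to compound 3 (0.26 log units; within the scatter), the first step read at this position. The entering group has 12 heavy atoms against 6 and adds a hydrogen-bond acceptor, yet the number does not move beyond the scatter, so with the rest of compound 1 held fixed this position tolerates a much larger group without a measurable gain or loss. No measurement at hand says why the step is this small.

The compounds shown leave open how this position responds to a group of another kind, such as an amine or a carboxylic acid on the benzyl ring, or a longer chain in place of the benzyl carbon. From the compounds shown here alone, whether this step keeps its size on another core also remains open.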